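One Stereocentre Changed in a Weakly Cytotoxic Acid

This account rests on a few compounds, and the source may have more. Where it says the series, first, only, none or still open, it means among the compounds named here.

Three compounds have values in a functional assay on HL-60 cells (Homo sapiens) for cytotoxicity, read by MTT assay, with a stated time of 48 h; a lower number here means a stronger inhibitor, a higher number a weaker inhibitor:
compound 1 `C=CC(=C)CC[C@@H]1[C@@]2(C)CCC[C@](C)(COC(=O)/C=C/c3ccc(O)cc3)[C@@H]2CC[C@@]1(C)O` gives 11800 nM;
compound 2 `C=CC(=C)[C@@H](O)C[C@H]1C(=C)CC[C@@H]2[C@]1(C)CCC[C@]2(C)C(=O)O` gives > 40000 nM;
compound 3 `C=CC(=C)CC[C@@H]1[C@@]2(C)CCC[C@](C)(COC(=O)/C=C/c3ccc(O)c(OC)c3)[C@@H]2CC[C@@]1(C)O` gives 14300 nM.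

For compound 2 the value is not a number but a limit of the assay, > 40000 nM, so compound 2 stands at the weak end of what was measured, with no number of its own. Among the compounds with values here, the only measured step between single-change neighbours is a 1.2-fold higher number from compound 1 to compound 3 (0.08 log units; within the scatter), a methoxy in place of hydrogen on an aromatic carbon, and it lies within the scatter. Within the data shown here, that step changes a substituent on compounds that are not compound 2, and no measured step concerns a change of configuration.

Compound 4 `C=CC(=C)[C@H](O)C[C@H]1C(=C)CC[C@@H]2[C@]1(C)CCC[C@]2(C)C(=O)O` differs from compound 2 as follows: the two compounds have the same atoms and bonds and differ only in configuration as drawn: 1 of 5 stereo elements differ; a stereocentre at a saturated chain carbon is drawn S in compound 2 and R in compound 4. Among the measured compounds shown here, no measured step bears on this change, so the expectation rests on the limit of compound 2 alone (the limit of > 40000 nM in this assay, at which 1 of the 3 values shown sits). Compound 4 is therefore expected to show no step beyond the scatter, that is a step that the limit leaves unreadable from compound 2 to compound 4, and most likely to be reported as a limit again. The estimate for compound 4 is 45000 nM, with a range from 15000 nM to 150000 nM.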

Compound 4, half-maximal inhibitory concentration: > 40000 nM
Compound 4: only a limit was reported (the forecaster's own chance of this, stated with the estimate: 75%); the middle value does not contradict the limit.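

In this assay, compound 2 and compound 4 are each reported only as a limit, not as a number, so no step can be read between these two compounds. The compounds shown leave open whether the configuration at this saturated chain carbon makes any difference to the result in this assay.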